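The source may hold more compounds than are shown below. What is called first, only, known or untested is meant among the compounds shown, and "the series" means these compounds.

In an ADME assay on BHK-21 cells (Mesocricetus auratus) for cytotoxicity, read by MTT assay, with a stated time of 72 h (a lower number here means that less compound is tolerated, a higher number that more compound is tolerated), compound 1 `NS(=O)(=O)c1ccc(N2N=C(c3ccccc3)CC2c2ccccc2F)cc1` gives 21000 nM and compound 3 `Cc1cccc(C2CC(c3ccccc3)=NN2c2ccc(S(N)(=O)=O)cc2)c1` gives 25000 nM while compound 2 `Cc1cccc(C2CC(c3ccc(Oc4ccccc4)cc3)=NN2c2ccc(S(N)(=O)=O)cc2)c1` gives 8000 nM as the lowest of the three numbers. Compound 4 `Cc1ccc(C2CC(c3ccc(Oc4ccccc4)cc3)=NN2c2ccc(S(N)(=O)=O)cc2)cc1` has not been measured yet and differs from compound 2 in one place (4-methylphenyl in place of 3-methylphenyl on a saturated ring carbon) with 4-methylphenyl in place of 3-methylphenyl on a saturated ring carbon. The step of a 3.1-fold higher number from compound 2 to compound 3 (0.49 log units; beyond the scatter) is modest but lies beyond the scatter, yet it removes the phenoxy group, which compound 4 keeps, so it says little about this change. Going by a swap on that same carbon (a 1.2-fold higher number from compound 1 to compound 3 (0.08 log units; within the scatter)) no step beyond the scatter is expected in this assay for this change. The estimated step is small (a 1.1-fold higher number from compound 2 to compound 4 (0.03 log units; within the scatter)) and has no expected direction. Compound 4 is estimated at 8500 nM with an expected range of 4500 nM to 16000 nM until it is measured.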

Compound 4, half-maximal cytotoxic concentration: 8000 nM
The estimate for compound 4 lay 1.1-fold (0.03 log units) above the measured number, and the stated range covers the measured number.
By their numbers in this assay, from the lowest: compounds 2 and 4 (each within the scatter of the next); then compounds 1 and 3 (each within the scatter of the next).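

In this assay, moving the methyl group to give 4-methylphenyl in place of 3-methylphenyl on this saturated ring carbon, with the phenoxy group kept, gives no change at the digits printed from compound 2 to compound 4 (within the scatter) and so no visible effect. Among the compounds shown here, the earlier swap on this carbon involved 2-fluorophenyl and had no phenoxy group, so this is the first reading of a change here with that group present. No measured evidence is available to explain this result. From the compounds shown here alone, whether an amine or a carboxylic acid in place of the methyl would shift the number remains open. Going by these compounds, it is also open whether 4-methylphenyl and 3-methylphenyl would still match without the phenoxy group.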